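A few compounds are considered here, and "the series" means these few. Any claim that something is new, unique, unknown or untested is made for them only; others in the source may bear on it.

Measured in a functional assay on HeLa cells (Homo sapiens) for antiproliferative activity, read by MTT assay, with a stated time of 48 h; on this read-out higher numbers stand for weaker inhibition and lower numbers for stronger inhibition:
Compound 1 `CCOc1cc(-c2ccc3[nH]ccc3c2)cn2c(-c3cc(OC)c(OC)c(OC)c3)nnc12`: 166 nM
Compound 2 `COc1cc(-c2nnc3c(OC)cc(-c4ccc5[nH]cc(C=O)c5c4)cn23)cc(OC)c1OC`: > 10000 nM

In this assay compound 2 has only a limit, > 10000 nM, and not a number. Compound 3 `COc1cc(-c2nnc3c(OC)cc(-c4ccc5c(ccn5C)c4)cn23)cc(OC)c1OC` has not yet been measured. It carries 1-methyl-1H-indol-5-yl in place of 3-formyl-1H-indol-5-yl on an aromatic carbon of the shared core: 1-methyl-1H-indol-5-yl in place of 3-formyl-1H-indol-5-yl on an aromatic carbon. Within the data shown here, no measured pair isolates this change, so the expectation is a loose one. Like compound 3, which also differs from it elsewhere, compound 1 has no formyl group, and compound 1 gives 166 nM. On that basis, a large step towards stronger inhibition in this assay is expected, well beyond the usual scatter. The estimated change is an at least 160-fold lower number from compound 2 to compound 3 (2.22 log units; beyond the scatter). For compound 3 the estimated value is 60 nM, with an expected range from 10 nM to 400 nM.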

Compound 3, half-maximal inhibitory concentration: 15 nM
The estimate for compound 3 lay 4.0-fold (0.60 log units) above the measured number; the range from low to high includes it.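

In this assay, 1-methyl-1H-indol-5-yl in place of 3-formyl-1H-indol-5-yl on this aromatic carbon of the shared core gives an at least 660-fold lower number from compound 2 to compound 3 (2.82 log units; beyond the scatter), so the group at this position alone can decide whether inhibition is seen at all. The change is a double one within the indole: the formyl group and its carbonyl leave, the single hydrogen-bond donor of the leaving group is gone, and a methyl group enters. The step can only be given as a lower bound because compound 2 stands at a limit, not a number: the limit of > 10000 nM in this assay, at which 1 of the 3 values shown sits.

The compounds shown do not separate the loss of the formyl group from the gain of the 1-methyl group. Going by these compounds, how an amine, a carboxylic acid or a longer chain in place of the formyl group would fare in this assay also remains open.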